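Permeability outlook for a dimethylphenyl analogue

The compounds below may be only part of what the source reports. "The series", "measured", "known", "first", "only" and "open" are said of these compounds alone.

Measured compounds:
compound 1 `Cc1ccccc1-c1nc(CN2CCC(C(=O)NCCCN3CC(C)(C)CC(C)(C)C3)CC2)c(C)o1` gives > 1390 10^-6 cm/s in a physicochemical assay for permeability, using PAMPA; a lower number here means that the compound crosses the layer more slowly, a higher number that the compound crosses the layer faster; this value is a limit of the assay.
compound 2 `Cc1ccccc1-c1nc(CN2CCC(C(=O)NCCCN3CCCCC3)CC2)c(C)o1` gives 34.5 10^-6 cm/s.
compound 3 `Cc1oc(-c2ccc(Cl)c(Cl)c2)nc1CN1CCC(C(=O)NCCCN2C[C@H](C)C[C@H](C)C2)CC1` gives 522 10^-6 cm/s.

Of the two plain numbers, compound 3 gives the higher and compound 2 the lower, a gap that lies beyond the usual scatter. Compound 4 `Cc1cccc(C)c1-c1nc(CN2CCC(C(=O)NCCCN3C[C@H](C)C[C@H](C)C3)CC2)c(C)o1` has not yet been measured. It differs from compound 3 in one place: 2,6-dimethylphenyl in place of 3,4-dichlorophenyl on an aromatic carbon. The only measured step among these compounds, an at least 40-fold lower number from compound 1 to compound 2 (1.60 log units; beyond the scatter), concerns the amine ring at the far end of the chain, not the aryl group on the five-membered aromatic ring with 1 nitrogen and 1 oxygen, so it gives no direct guide to the present change. Within the data shown here, the two groups that are exchanged carry no hydrogen-bond donors or acceptors and no net charge, and the data hold no example of such an aryl swap. A step from compound 3 to compound 4 no larger than the scatter is therefore expected, with the uncertainty widened by the lack of a matching example: a 1.2-fold lower number from compound 3 to compound 4 (0.06 log units; within the scatter). Compound 4 is expected to give about 450 10^-6 cm/s in this assay, within 150 10^-6 cm/s to 1300 10^-6 cm/s.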

Compound 4, apparent permeability: 254 10^-6 cm/s
Estimate against measurement, compound 4: 1.8-fold (0.25 log units) above; low and high end bracket the measured number.
By their numbers in this assay, from the lowest: compound 2; then compound 4; then compound 3. At a limit, above all of these: compound 1.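

Among these compounds, this is the first step in the set that concerns the aryl group on the five-membered aromatic ring with 1 nitrogen and 1 oxygen, and it shows that a change at this position can register in this assay: a 2.1-fold lower number from compound 3 to compound 4 (0.31 log units; beyond the scatter). The exchange is a close one on the counts, since 3,4-dichlorophenyl and 2,6-dimethylphenyl have the same count of heavy atoms, no hydrogen-bond donors or acceptors and no net charge, yet the step is printed as just beyond the scatter and so counts as modest, whereas the step at the amine ring at the far end of the chain, an at least 40-fold lower number from compound 1 to compound 2 (1.60 log units; beyond the scatter), is large. Nothing measured here accounts for the size or direction of the step at the aryl group.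

The two aryl groups differ both in the atoms they carry, chlorine or methyl carbon, and in where these stand on the ring, so this single step cannot separate the two differences. Going by these compounds, how a plain phenyl group, a methoxyphenyl group or a pyridyl ring would behave at this position also remains open, as does whether the step would be the same size with a different amine ring at the far end of the chain.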